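A few compounds are considered here, and "the series" means these few. Any claim that something is new, unique, unknown or untested is made for them only; others in the source may bear on it.

Series on the shared core of compound 2 `O=C(Nc1ccc2nc(NC(=O)C3CCCCC3)sc2c1)c1c(Cl)cccc1Cl`. In a functional assay on WI-38 VA13 cells (Homo sapiens) for cytotoxicity (on this read-out lower numbers stand for an effect already at smaller amounts and higher numbers for an effect only at larger amounts of compound), compound 2 gives 0.015 ug/mL, the lowest of the two numbers available. Compound 3 `C=CCOC(=O)Nc1ccc2nc(NC(=O)C3CCCCC3)sc2c1` gives 0.58 ug/mL in this assay. Compound 1 `O=C(Nc1ccc2nc(NC(=O)C3CCCCC3)sc2c1)c1ccc(Br)cc1` reaches only a limit of this assay, > 4 ug/mL. All measured steps sit on the same carbonyl carbon: an at least 260-fold lower number from compound 1 to compound 2 (2.42 log units; beyond the scatter), an at least 6.8-fold lower number from compound 1 to compound 3 (0.83 log units; beyond the scatter) and a 39-fold higher number from compound 2 to compound 3 (1.59 log units; beyond the scatter), each beyond the scatter, with the two steps from compound 1 bounded by the limit of > 4 ug/mL in this assay, at which 1 of the 3 values shown sits.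

Compound 4 `NCCC(=O)Nc1nc2ccc(NC(=O)c3c(Cl)cccc3Cl)cc2s1` differs from compound 2 at the other amide: 2-aminoethyl in place of cyclohexyl on a carbonyl carbon. Among the measured compounds shown here, no measured step touches this carbonyl carbon, so none bears on the change directly; the measured steps show only that a single change can move this assay by a large amount. A step beyond the scatter is therefore expected for compound 4, while its direction cannot be read from the three compounds. Compound 4 is estimated at 0.3 ug/mL, range 0.03 ug/mL to 3 ug/mL. That estimate means an expected 20-fold higher number from compound 2 to compound 4 (1.30 log units; beyond the scatter).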

Compound 4, half-maximal effective concentration: 5.3 ug/mL
For compound 4 the middle estimate is 18-fold (1.25 log units) below the measured one; the measured number lies above the stated range.
By their numbers in this assay, from the lowest: compound 2; then compound 3; then compound 4.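

In this assay, among the compounds shown here, 2-aminoethyl in place of cyclohexyl gives a 350-fold higher number from compound 2 to compound 4 (2.55 log units; beyond the scatter) and shows that this carbonyl carbon, with the 2,6-dichlorophenyl end held fixed, is as sensitive as the one carrying all the earlier steps. The change removes a six-membered non-aromatic ring of carbon only and brings in an open chain with one nitrogen, so loss of the ring, the smaller group and the entering amine all travel together in this one step. Nothing measured on these compounds gives a cause for the step.

Which of these parts carries the step remains open. An ethyl or propyl chain without the amine, or an aminocyclohexyl group, on this carbonyl carbon would separate them, and a longer aminoalkyl chain would show whether chain length matters at all.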